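Carbamate series: swapping an amide for an ester

A few compounds are considered here, and "the series" means these few. Any claim that something is new, unique, unknown or untested is made for them only; others in the source may bear on it.

Of the compounds shown here, three share a carbamate-bearing core and have been measured in an assay on isolated protein for inhibition of Fatty-acid amide hydrolase 1 (Homo sapiens), read by fluorescence, with a stated time of 30 min; a lower number here means a stronger inhibitor, a higher number a weaker inhibitor. Compound 1 `CC(C)NC(=O)c1cc(-c2cccc(OC(=O)NC3CCCCC3)c2)n(-c2ccccc2)n1` gives 232 nM. Compound 2 `Cn1nc(C(N)=O)cc1-c1ccc(OC(=O)NC2CCCCC2)cc1` gives 209 nM, and compound 3 `NC(=O)c1cc(-c2ccc(OC(=O)NC3CCCCC3)cc2)n(-c2ccc(Cl)cc2)n1` gives 172 nM. Compound 1 holds the highest of the three numbers, but its gaps to compound 2 and to compound 3 both lie within the scatter, so the three are indistinguishable on these data. Within the data shown here, the one single-point step, a 1.2-fold lower number from compound 2 to compound 3 (0.08 log units; within the scatter), swaps a 4-chlorophenyl for a methyl on an aromatic nitrogen and is also within the scatter.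

Compound 4 `COC(=O)c1cc(-c2cccc(OC(=O)NC3CCCCC3)c2)n(-c2ccccc2)n1` differs from compound 1 at the carbonyl carbon attached to the core: methoxy in place of isopropylamino on a carbonyl carbon. Among the measured compounds shown here, no measured step touches this position; the step from compound 2 to compound 3 concerns a different part of the molecule, and compounds 2 and 3 carry an unsubstituted carbamoyl rather than a methoxycarbonyl, so they offer no direct guide either. With nothing in the data pointing one way, the expectation for this assay is a step of about a 1.5-fold higher number from compound 1 to compound 4 (0.18 log units; within the scatter), with wide uncertainty. Compound 4 is therefore estimated at 350 nM, expected to fall between 110 nM and 1200 nM.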

Compound 4, half-maximal inhibitory concentration: 18 nM
Compound 4: the middle estimate sits 19-fold (1.29 log units) above what was measured; measured number below the stated range.
By their numbers in this assay, from the lowest: compound 4; then compounds 3, 2 and 1 (each within the scatter of the next).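

Among these compounds, until now, the only step that could be read lay at the aromatic nitrogen and stayed within the scatter, so nothing showed that one change could move the number much. The carbonyl carbon attached to the core proves to be such a place: in this assay, methoxy in place of isopropylamino gives a 13-fold lower number from compound 1 to compound 4 (1.11 log units; beyond the scatter), a large step well beyond the scatter. Several things change together in this one swap, since the group loses heavy atoms, gives up its hydrogen-bond donor and brings in a hydrogen-bond acceptor, so the step alone cannot show which of these matters.

No measurement at hand accounts for a step of this size. The compounds shown also leave open whether the lower number is specific to methoxy or follows from removing the isopropylamino group, a question that a carboxylic acid, an ethoxy group or a plain unsubstituted amide on the same carbonyl carbon of the core of compound 1 could help to answer.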